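This account rests on a few compounds, and the source may have more. Where it says the series, first, only, none or still open, it means among the compounds named here.

Of the compounds shown here, two have numbers so far. In a functional assay on SMMC-7721 cells (Homo sapiens) for cytotoxicity, read by MTT assay, with a stated time of 72 h (on this read-out higher numbers stand for weaker inhibition and lower numbers for stronger inhibition), compound 1 `O=C1C(=Cc2ccc(O)cc2)C(=O)N(c2ccc(Cl)cc2)N1c1ccc(Cl)cc1` gives 20600 nM and compound 2 `COc1cccc(C=C2C(=O)N(c3ccc(Cl)cc3)N(c3ccc(Cl)cc3)C2=O)c1O` gives 64900 nM, the higher of the two numbers and so the weaker inhibition. Compound 3 `COc1ccc(C=C2C(=O)N(c3ccc(Cl)cc3)N(c3ccc(Cl)cc3)C2=O)cc1` is still unmeasured. Its change from compound 2 is 4-methoxyphenyl in place of 2-hydroxy-3-methoxyphenyl on a double-bonded chain carbon bound to a double-bonded ring carbon. For the measured compounds named here, only one measured step bears on this place, a 3.2-fold higher number from compound 1 to compound 2 (0.50 log units; beyond the scatter), which is modest and beyond the scatter. Compound 1 carries 4-hydroxyphenyl there, so compound 3 is expected to fall back part of the way in this assay, toward a lower number, though one step is thin support. The expected change is a 2.0-fold lower number from compound 2 to compound 3 (0.29 log units; within the scatter). The estimate for compound 3 is 33000 nM, with an expected range of 13000 nM to 80000 nM.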

Compound 3, half-maximal inhibitory concentration: > 128000 nM
Compound 3 was reported as a limit; the forecaster's own chance of this, stated with the estimate: 10%; middle value at least 3.8-fold (0.58 log units) from the limit.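

Compound 3 is reported only as a limit, not as a number, in this assay: the limit of > 128000 nM in this assay, at which 1 of the 3 values shown sits.

The comparison with compound 1 isolates a single change at this position, methyl in place of hydrogen on an oxygen on an aromatic ring, and gives an at least 6.2-fold higher number from compound 1 to compound 3 (0.79 log units; beyond the scatter), so capping the hydroxy oxygen weakens inhibition beyond the scatter. The comparison with compound 2 gives an at least 1.9-fold higher number from compound 2 to compound 3 (0.29 log units; that floor lies within the scatter); that floor alone does not establish an order between the two compounds.

From the compounds shown here alone, the true size of both steps stays open, since the limit sets only their floors. Also open, going by these compounds, is whether the loss is specific to methyl on that oxygen, or whether an amine or a carboxylic acid in place of the hydroxy group would keep a measurable number in this assay.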